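The compounds below may be only part of what the source reports. "The series", "measured", "known", "first", "only" and "open" are said of these compounds alone.

In a functional assay on HeLa cells (Homo sapiens) for cytotoxicity, read by MTT assay, with a stated time of 72 h (on this read-out lower numbers stand for stronger inhibition and higher numbers for weaker inhibition), compound 1 (`COC(=O)c1sc2c(C)cccc2c1Nc1cc(OC)c(OC)c(OC)c1`) gives 1730 nM and compound 2 (`COC(=O)c1sc2cc(OC)ccc2c1Nc1cc(OC)c(OC)c(OC)c1`) gives 0.28 nM as the lower of the two numbers, a gap well beyond the usual scatter. Compound 3 (`COC(=O)c1sc2cc(C)ccc2c1Nc1cc(OC)c(OC)c(OC)c1`) has not been measured yet. It departs from compound 2 at a single place, with methyl in place of methoxy on an aromatic carbon. For the measured compounds named here, no measured pair shows this change alone, so its size is uncertain, but a weakening beyond the scatter is expected in this assay on this evidence. The expected step is a 54-fold higher number from compound 2 to compound 3 (1.73 log units; beyond the scatter) (an estimate). Compound 3 is estimated at 15 nM (range 1 nM to 200 nM).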

Compound 3, half-maximal inhibitory concentration: 0.31 nM
Beside the measured number, compound 3's estimate is 48-fold (1.68 log units) above it; measured number below the stated range.
By their numbers in this assay, from the lowest: compounds 2 and 3 (each within the scatter of the next); then compound 1.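

In this assay the swap of methoxy for methyl gives a 1.1-fold higher number from compound 2 to compound 3 (0.04 log units; within the scatter), so the two compounds cannot be told apart. At this place on the ring, then, the oxygen atom and the hydrogen-bond acceptor counted for methoxy are not required for a number this low. Nothing measured here explains why this swap is tolerated.

The compounds shown leave open whether a plain hydrogen, an amine, a carboxylic acid or a longer chain such as butyl at this place would keep the number this low.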